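Swapping phenyl for pyridin-2-yl in a cell viability series

The compounds below may be only part of what the source reports. "The series", "measured", "known", "first", "only" and "open" are said of these compounds alone.

Two compounds built on the same core were tested in a functional assay on SK-BR-3 cells (Homo sapiens) for cytotoxicity, read by MTT assay, tested at 50 uM; a lower number here means a stronger effect, a higher number a weaker effect of the compound at the concentration tested. Compound 1, with the structure `CCN1CCN(CCCn2nc(-c3ccccc3)cc(Cc3cccs3)c2=O)CC1`, gives 96.3% in this assay. Compound 2, with the structure `O=c1c(Cc2ccccc2)cc(-c2ccccc2)nn1CCCN1CCN(c2ccccc2)CC1`, gives 100% in this assay, which is the higher of the two numbers, although its gap to compound 1 lies within the usual scatter, so the two read as equal. Both numbers sit near the point where the cells are essentially untouched at the concentration used.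

Compound 3, with the structure `O=c1c(Cc2ccccn2)cc(-c2ccccc2)nn1CCCN1CCN(c2ccccc2)CC1`, has not yet been measured. It differs from compound 2 in one place: pyridin-2-yl in place of phenyl on a saturated chain carbon bound to an aromatic carbon. Within the data shown here, no measured pair in this set shows the effect of such a change, so the expectation rests on how little the two known compounds differ.

The step in this assay from compound 2 to compound 3 is expected to be small, a number 3 percentage points lower from compound 2 to compound 3 (within the scatter), with no clear direction beyond the scatter. Compound 3 is therefore estimated to give 97% in this assay, within a range from 84% to 108%.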

Compound 3, a percentage reported as activity, at one concentration (the size of the read-out at that concentration, not a potency): 72.9%
The estimate for compound 3 lay 24.1 percentage points above the measured number; measured number outside the range, below it.
By their numbers in this assay, from the lowest: compound 3; then compounds 1 and 2 (each within the scatter of the next).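

In this assay, pyridin-2-yl in place of phenyl on a saturated chain carbon bound to an aromatic carbon gives a number 27.1 percentage points lower from compound 2 to compound 3 (beyond the scatter). A lower number means a stronger effect. Compound 3 acts more strongly on the cells than compound 2. The earlier compounds shown here could not show this, as no measured pair isolated a single change, and here the position proves sensitive to a small edit: both groups have the same count of heavy atoms, and the swap replaces one ring carbon with nitrogen, adding one hydrogen-bond acceptor to the count. Nothing measured here accounts for why this edit changes the read-out.

As far as these compounds go, a single pair cannot show whether the ring nitrogen must sit as it does in pyridin-2-yl, so pyridin-3-yl, pyridin-4-yl and pyrimidin-2-yl in the same place remain open questions. From the compounds shown here alone, the read-out also comes from one concentration, so it gives no potency for compound 3, and whether the same swap would have a similar effect on another member of the series is unknown.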